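Thiosemicarbazone series: ortho substituent swap on the aryl ring

This account rests on a few compounds, and the source may have more. Where it says the series, first, only, none or still open, it means among the compounds named here.

Measured compounds:
compound 1 `CC1=CC[C@H](C(C)(C)NC(=S)N/N=C/c2ccc(O)cc2)CC1` — 53800 nM
compound 2 `CC1=CC[C@H](C(C)(C)NC(=S)N/N=C/c2ccccc2O)CC1` — 900 nM

In a functional assay on PC-3 cells (Homo sapiens) for inhibition, read by sulforhodamine B assay, with a stated time of 48 h (a lower number here means a stronger inhibitor of growth, a higher number a weaker inhibitor of growth), compound 1 gives 53800 nM, and compound 2 gives 900 nM. Among the measured compounds shown here, the one measured step, a 60-fold lower number from compound 1 to compound 2 (1.78 log units; beyond the scatter), moves the hydroxy from one aromatic carbon to another. Compound 2 therefore stands at the lowest number of the two, with compound 1 as the only comparator.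

Compound 3 `CC1=CC[C@H](C(C)(C)NC(=S)N/N=C/c2ccccc2[N+](=O)[O-])CC1` differs from compound 2 by nitro in place of hydroxy on an aromatic carbon. For the measured compounds named here, no measured step changes the identity of the group at this position; the step from compound 1 to compound 2 only shows that this assay is sensitive to what sits on the aryl ring. The hydroxy that leaves is a donor; the nitro that enters carries none. Given the absence of a direct precedent, a modest loss of potency with a wide range is expected for compound 3, a 3.3-fold higher number from compound 2 to compound 3 (0.52 log units; beyond the scatter), giving an estimate of 3000 nM (range 600 nM to 20000 nM).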

Compound 3, concentration for total growth inhibition: 6400 nM
The estimate for compound 3 lay 2.1-fold (0.33 log units) below the measured number; measured number inside the range.
By their numbers in this assay, from the lowest: compound 2; then compound 3; then compound 1.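

In this assay, nitro in place of hydroxy on an aromatic carbon ortho to a large group gives a 7.1-fold higher number from compound 2 to compound 3 (0.85 log units; beyond the scatter) and so raises the number. The earlier step showed the effect of moving the hydroxy; this one shows that the identity of the group at this place also changes the number, with hydroxy giving the lower number of the two groups compared here. A hydrogen-bond donor in this group is not required for a measurable number, since compound 3 carries none and gives 6400 nM, but one pair cannot separate the features that differ between hydroxy and nitro, and no available evidence bears on the cause.
Open, on these data alone, is how an amine, a methoxy or a fluorine on this same carbon would compare with hydroxy and nitro. Also open, as far as these compounds go, is whether nitro would keep the same standing against hydroxy on the ring carbon that carries the hydroxy in compound 1.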